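This account rests on a few compounds, and the source may have more. Where it says the series, first, only, none or still open, it means among the compounds named here.

Working notes on the series. Compound 3 `O=C(O)Cc1sc(C(c2ccc(F)cc2)c2ccc(F)cc2)nc1-c1ccc(Cl)cc1` holds the highest of the three maximal responses in an in vitro functional assay on HEK285-7 cells for antagonist activity at prostaglandin D2 receptor 2 (Homo sapiens), read by BRET and beta-arrestin recruitment; a higher number here means a larger maximal response, a lower number a smaller maximal response: compound 3 reaches 80%. Compound 1 `COc1cc(-c2nc(C(c3ccc(F)cc3)c3ccc(F)cc3)sc2CC(=O)O)ccn1` comes nearest to it, giving 60% in this assay, while compound 2 `N#Cc1ccc(-c2nc(C(c3ccc(F)cc3)c3ccc(F)cc3)sc2CC(=O)O)cc1` lies furthest, at 30%. The two steps ending at compound 3 are a number 20 percentage points higher from compound 1 to compound 3 (beyond the scatter) and a number 50 percentage points higher from compound 2 to compound 3 (beyond the scatter); the third, a number 30 percentage points lower from compound 1 to compound 2 (beyond the scatter), runs the other way.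

Compound 4 `CN(C)c1cc(-c2nc(C(c3ccc(F)cc3)c3ccc(F)cc3)sc2CC(=O)O)ccn1` is the next member, and its difference from compound 3 is 2-(dimethylamino)pyridin-4-yl in place of 4-chlorophenyl on an aromatic carbon. The step from compound 1 to compound 3, a number 20 percentage points higher from compound 1 to compound 3 (beyond the scatter), bears most directly on this change: compound 1 carries 2-methoxypyridin-4-yl where compound 4 carries 2-(dimethylamino)pyridin-4-yl, both standing in place of the 4-chlorophenyl of compound 3. Among the compounds with values here, no measured compound carries the 2-(dimethylamino)pyridin-4-yl group itself, so the exact size attaching to this group is unknown. The expectation is a modest fall in this assay, roughly undoing the rise seen from compound 1 to compound 3. The step is therefore expected to be a number 20 percentage points lower from compound 3 to compound 4 (beyond the scatter). Compound 4 is estimated at 60%, within a range from 40% to 80%.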

Compound 4, largest response reached (reported as efficacy), in percent of the reference or control that the assay uses: 80%
Estimate against measurement, compound 4: 20 percentage points below; the measured number falls inside the stated range.
By their numbers in this assay, from the lowest: compound 2; then compound 1; then compounds 3 and 4 (each within the scatter of the next).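

In this assay, the result at this position, on the aromatic carbon next to the ring nitrogen, is no change at the digits printed from compound 3 to compound 4 (within the scatter), so here the 2-(dimethylamino)pyridin-4-yl group cannot be told apart from 4-chlorophenyl. Within the data shown here, the exchange of methoxy for dimethylamino on the pyridinyl group gives a number 20 percentage points higher from compound 1 to compound 4 (beyond the scatter) and is the first step made on that group alone, while a number 50 percentage points higher from compound 2 to compound 4 (beyond the scatter) sets the new group as far from 4-cyanophenyl as 4-chlorophenyl stands. No measured evidence accounts for the difference between dimethylamino and methoxy on this group.

Open, from the compounds shown here alone, is whether another amine at the same place on the pyridinyl group, such as a pyrrolidin-1-yl or a plain amino group, would keep the response of compound 4 or fall back towards that of compound 1. Also open, going by these compounds, is how 4-(dimethylamino)phenyl and an unsubstituted pyridin-4-yl would stand, since these two groups would separate the contribution of the dimethylamino group from that of the ring nitrogen.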